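Swapping the trifluoromethylphenyl arm of compound 2 for fluorophenyl

A few compounds are considered here, and "the series" means these few. Any claim that something is new, unique, unknown or untested is made for them only; others in the source may bear on it.

Compound 2 `CC(C)(C)CC[C@H](c1ccc(C(=O)NCc2nn[nH]n2)cc1)N1C(=O)C(c2cccc(C(F)(F)F)c2)=N[C@]12CC[C@@H](C(C)(C)C)CC2` gives 13 nM in an assay on CHO cells for displacement of a labelled ligand from Glucagon receptor (Homo sapiens), read by scintillation counting, with a stated time of 60 min (a higher number here means a weaker inhibitor, a lower number a stronger inhibitor), and holds the lowest number of the three measured compounds. Compound 1 `C[C@H](c1ccc(C(=O)NCCC(=O)O)cc1)N1C(=O)C(c2cccc(OC(F)(F)F)c2)=N[C@]12CC[C@@H](C(C)(C)C)CC2` gives 330 nM and compound 3 `C[C@H](c1ccc(C(=O)NCCC(=O)O)cc1)N1C(=O)C(c2cccc(F)c2)=N[C@]12CC[C@@H](C(C)(C)C)CC2` gives 490 nM in this assay. Compound 4 `CC(C)(C)CC[C@H](c1ccc(C(=O)NCc2nn[nH]n2)cc1)N1C(=O)C(c2ccc(F)cc2)=N[C@]12CC[C@@H](C(C)(C)C)CC2` differs from compound 2 only in 4-fluorophenyl in place of 3-(trifluoromethyl)phenyl on a carbon with a double bond to nitrogen. Among the compounds with values here, the one measured step that bears on this, fluoro in place of trifluoromethoxy in the same part of the shared core, is a 1.5-fold higher number from compound 1 to compound 3 (0.17 log units; within the scatter). That step is small, but the present change also moves the single fluorine to a different carbon of the ring, so a modest loss is expected, a 2.3-fold higher number from compound 2 to compound 4 (0.36 log units; beyond the scatter). Compound 4 is estimated at 30 nM, within 10 nM to 100 nM.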

Compound 4, half-maximal inhibitory concentration: 13 nM
Compound 4: the middle estimate sits 2.3-fold (0.36 log units) above what was measured; measured number inside the range.
By their numbers in this assay, from the lowest: compounds 2 and 4 (each within the scatter of the next); then compounds 1 and 3 (each within the scatter of the next).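

Putting 4-fluorophenyl in place of 3-(trifluoromethyl)phenyl gives no change at the digits printed from compound 2 to compound 4 (within the scatter) in this assay. Unlike the earlier step, this one changes the aromatic arm itself, from 10 heavy atoms to 7, and the ring carbon that carries the substituent, yet the number holds. No measurement available here explains this result. The compounds shown leave open whether a plain phenyl or an amine at this carbon would hold the number in this assay. They also leave open whether 4-fluorophenyl would do the same alongside the propanoic acid side chain of compound 1.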